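The source may hold more compounds than are shown below. What is called first, only, known or untested is meant among the compounds shown, and "the series" means these compounds.

Three related compounds were examined in an ADME assay on NIH3T3 cells (Mus musculus) for cytotoxicity, read by MTT assay, with a stated time of 24 h; on this read-out lower numbers stand for stronger inhibition and higher numbers for weaker inhibition. Compound 1 `COc1ccc(-c2nnc(N3CCN(C(=O)CN4CCN(c5cccc(OC)c5)CC4)CC3)nc2-c2ccc(OC)cc2)cc1` carries a 3-methoxyphenyl on its outer piperazine. In this assay compound 1 gives > 821000 nM, which is a limit of the assay rather than a number. Compound 2 `COc1ccc(-c2nnc(N3CCN(C(=O)CN4CCN(c5cccc(Cl)c5)CC4)CC3)nc2-c2ccc(OC)cc2)cc1` differs from compound 1 by chloro in place of methoxy on an aromatic carbon. In this assay compound 2 gives > 814000 nM, again a limit. The step that the two limits leave unreadable from compound 1 to compound 2 cannot be sized, as the limit of > 821000 nM in this assay, at which 1 of the 3 values shown sits, and the limit of > 814000 nM in this assay, at which 1 of the 3 values shown sits, show.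

Compound 3 `COc1ccc(N2CCN(CC(=O)N3CCN(c4nnc(-c5ccc(Cl)cc5)c(-c5ccc(Cl)cc5)n4)CC3)CC2)cc1` is built on a different core; the difference between the cores of compound 1 and compound 3 is not broken down here. In this assay compound 3 gives > 809000 nM, also a limit, as the limit of > 809000 nM in this assay, at which 1 of the 3 values shown sits, records.

Compound 4 `O=C(CN1CCN(c2ccc(Cl)cc2)CC1)N1CCN(c2nnc(-c3ccc(Cl)cc3)c(-c3ccc(Cl)cc3)n2)CC1` has not yet been measured. It differs from compound 3 by chloro in place of methoxy on an aromatic carbon. This is the same kind of change as that from compound 1 to compound 2, though the place is not identical: there the chloro sits meta to a large group, here para to a large group.

The step that the limit leaves unreadable from compound 3 to compound 4 is expected to be small. That expectation rests on compound 3, whose value > 809000 nM is a limit, and on the earlier pair, where the step that the two limits leave unreadable from compound 1 to compound 2 gave no readable size. Compound 4 is therefore estimated at 1000000 nM in this assay, within a range from 400000 nM to 3000000 nM, and most likely the assay will again report only a limit.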

Compound 4, half-maximal inhibitory concentration: > 803000 nM
Compound 4 was reported as a limit; the forecaster's own chance of this, stated with the estimate: 85%; the middle value is on the limit's open side.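

In this assay compound 4 gives > 803000 nM, which is a limit of the assay and not a number. Compound 3 is also recorded only as a limit, so no step can be read from compound 3 to compound 4. The compounds shown leave open whether chloro in place of methoxy changes the read-out at all, and at what concentration any of the four would reach half-maximal inhibition.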